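The source may report more compounds than this note shows. Statements on the series, on what has been measured and on what is new or still open speak of the compounds shown alone.

Compound 1 `Cc1cc(O)c(C(C)C)cc1-c1cc(-c2ccccc2Cl)c(C#N)c(=O)[nH]1` gives 32% in a functional assay for inhibition, tested at 80 ug/mL; on this read-out higher numbers stand for a stronger effect at the one concentration tested and lower numbers for a weaker effect.
Compound 2 `COc1ccc(-c2cc(-c3cc(C(C)C)c(O)cc3C)[nH]c(=O)c2C#N)c(OC)c1` gives 55%.
Compound 3 `Cc1cc(O)c(C(C)C)cc1-c1cc(-c2ccco2)c(C#N)c(=O)[nH]1` gives 64%.

Compound 2 stands second highest of the three: its nearest neighbour is compound 3, with a number 9 percentage points higher from compound 2 to compound 3 (within the scatter), and its furthest is compound 1, with a number 23 percentage points higher from compound 1 to compound 2 (beyond the scatter). Compound 4 `COc1cccc(-c2cc(-c3cc(C(C)C)c(O)cc3C)[nH]c(=O)c2C#N)c1` differs from compound 2 by 3-methoxyphenyl in place of 2,4-dimethoxyphenyl on an aromatic carbon. For the measured compounds named here, two measured steps bear on this position, a number 23 percentage points higher from compound 1 to compound 2 (beyond the scatter) and a number 9 percentage points higher from compound 2 to compound 3 (within the scatter), and a third, a number 32 percentage points higher from compound 1 to compound 3 (beyond the scatter), shows the widest span seen there. Going by the values given here, no measured step compares a 2,4-dimethoxyphenyl with a 3-methoxyphenyl, so the direction is uncertain. Compound 4 is therefore expected to show a number 7 percentage points lower from compound 2 to compound 4 (within the scatter), a move judged to lie within the scatter. Compound 4 is estimated at 48%, between 30% and 66%.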

Compound 4, a percentage reported as inhibition, at one concentration (the size of the read-out at that concentration, not a potency): 43%
Estimate against measurement, compound 4: 5 percentage points above; the measured number falls inside the stated range.
By their numbers in this assay, from the lowest: compound 1; then compound 4; then compounds 2 and 3 (each within the scatter of the next).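

In this assay, for the compounds shown here, the step of a number 12 percentage points lower from compound 2 to compound 4 (beyond the scatter) is the first comparison of two methoxy-bearing phenyl groups at this position, and it shows that a methoxy group on the phenyl does not by itself fix the read-out. The step of a number 11 percentage points higher from compound 1 to compound 4 (beyond the scatter) and the step of a number 21 percentage points lower from compound 3 to compound 4 (beyond the scatter) set 3-methoxyphenyl apart from 2-chlorophenyl and from furan-2-yl as well. Nothing measured here accounts for these differences.

Left open is whether the step from 2,4-dimethoxyphenyl follows the number of methoxy groups or their placement, which a 4-methoxyphenyl group could address. On these data alone, how an amine or a carboxylic acid on this phenyl would read also stays open.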